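Removing one chloro from the core of compound 1

The source may report more compounds than this note shows. Statements on the series, on what has been measured and on what is new or still open speak of the compounds shown alone.

Two compounds of this set carry a chloromethyl-bearing benzyl group on a dichlorinated bicyclic core and have been measured in a functional assay on UACC-62 cells (Homo sapiens) for cytotoxicity, read by sulforhodamine B assay, with a stated time of 48 h; on this read-out higher numbers stand for weaker inhibition of growth and lower numbers for stronger inhibition of growth. Compound 1 `ClCc1cccc(Cn2cnc3c(Cl)nc(Cl)nc32)c1` gives 3460 nM in this assay. Compound 2 `ClCc1cccc(Cn2cnc3nc(Cl)nc(Cl)c32)c1`, which places the benzyl group on a different ring nitrogen of the same core, gives 2180 nM in this assay. The gap between the two numbers lies within the usual scatter, so the values of compound 1 and compound 2 are not separated from each other. Going by the values given here, no pair differing in a single place has been measured, so no step size is known from the data so far.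

Compound 3 `ClCc1cccc(Cn2cnc3c(Cl)ncnc32)c1` is the next compound for this assay. Relative to compound 1 the change is hydrogen in place of chloro on an aromatic carbon. Among the compounds with values here, with no measured step to lean on, the expectation is a modest move in this assay toward a higher number, expressed as a 1.6-fold higher number from compound 1 to compound 3 (0.20 log units; within the scatter), with considerable uncertainty in either direction. On that basis compound 3 is estimated at 5500 nM in this assay, within a range from 2000 nM to 15000 nM.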

Compound 3, concentration for total growth inhibition: 3380 nM
Estimate against measurement, compound 3: 1.6-fold (0.21 log units) above; the measured number falls inside the stated range.
By their numbers in this assay, from the lowest: compounds 2, 3 and 1 (each within the scatter of the next).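

In this assay, going by these compounds alone, the first single-place step, hydrogen in place of chloro on an aromatic carbon, is a 1.0-fold lower number from compound 1 to compound 3 (0.01 log units; within the scatter), which lies within the scatter. At this position, between two ring nitrogen atoms, the read-out therefore does not separate chloro from hydrogen, and the chloro group here is not required for a value in the range of compound 1. No measurement shown offers an explanation for this result.

As far as these compounds go, it remains open whether a larger or different substituent at this position, such as an amine or a methoxy group, would give a step beyond the scatter, since only chloro and hydrogen are compared here. The contributions of the remaining chloro on the core and of the chloromethyl group on the benzyl ring also remain unresolved, as does whether the same replacement in compound 2 would give a similar step.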